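Swapping the halogenated phenyl on the sulfanylmethyl arm

The source may report more compounds than this note shows. Statements on the series, on what has been measured and on what is new or still open speak of the compounds shown alone.

Two nucleoside analogues have been measured in an assay on isolated protein for binding affinity to Equilibrative nucleoside transporter 1 (Homo sapiens); a higher number here means a weaker inhibitor, a lower number a stronger inhibitor. Compound 1 `CCCCCNc1ncnc2c1ncn2[C@@H]1O[C@H](CO)[C@@H](O)[C@H]1O` carries a pentylamino group on the shared core and in this assay compound 1 gives 13500 nM. Compound 2 `OC[C@H]1O[C@@H](n2cnc3c(CSc4ccccc4Cl)ncnc32)[C@H](O)[C@@H]1O` instead carries a ((2-chlorophenyl)sulfanyl)methyl group, and in this assay compound 2 gives 1780 nM; the change gave a 7.6-fold lower number from compound 1 to compound 2 (0.88 log units; beyond the scatter). On the numbers in hand compound 2 therefore stands as the lower of the two, and its value is the starting point for the next comparison.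

Compound 3 `OC[C@H]1O[C@@H](n2cnc3c(CSc4ccc(I)cc4)ncnc32)[C@H](O)[C@@H]1O` keeps the sulfanylmethyl arm of compound 2 and alters only the aryl group on the sulfur: 4-iodophenyl in place of 2-chlorophenyl on a sulfur. Among the compounds with values here, no measured step touches this position; the only step recorded, from compound 1 to compound 2, changes the whole substituent on the aromatic carbon of the core and so gives no guide to what a different halophenyl on the sulfur will do. With nothing to anchor a direction, the expectation is for a step of a 1.2-fold lower number from compound 2 to compound 3 (0.07 log units; within the scatter), within the scatter, in this assay. Compound 3 is accordingly estimated at 1500 nM, with a range from 400 nM to 6000 nM.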

Compound 3, half-maximal inhibitory concentration: 69.2 nM
Estimate against measurement, compound 3: 22-fold (1.34 log units) above; the whole stated range lies above it.
By their numbers in this assay, from the lowest: compound 3; then compound 2; then compound 1.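

In this assay, the aryl group on the sulfur proves far from a neutral place to make a change: 4-iodophenyl in place of 2-chlorophenyl gives a 26-fold lower number from compound 2 to compound 3 (1.41 log units; beyond the scatter) even though the two groups have the same heavy-atom count and neither has a hydrogen-bond donor or acceptor. The earlier comparison changed the whole substituent on the aromatic carbon, whereas this one shows that the identity of the aryl group alone can move the number substantially, and the full replacement of pentylamino now amounts to a 200-fold lower number from compound 1 to compound 3 (2.29 log units; beyond the scatter) in the same assay. Nothing available here accounts for why this exchange has so large an effect.

The exchange alters both the halogen and its place on the ring, so the step cannot be divided between the two without 4-chlorophenyl or 2-iodophenyl on the sulfur. Also open, going by these compounds, is how a plain phenyl or a 4-methoxyphenyl group would read there, and thus whether a halogen is needed on this ring at all.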